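This account rests on a few compounds, and the source may have more. Where it says the series, first, only, none or still open, it means among the compounds named here.

Compound 1 `Clc1ccc(-c2nnc(-c3cn4ccccc4n3)o2)cc1` gives 32800 nM in a functional assay on DU-145 cells (Homo sapiens) for antiproliferative activity, read by MTT assay, with a stated time of 48 h; a lower number here means a stronger inhibitor, a higher number a weaker inhibitor. Compound 2 `Brc1ccc(-c2nnc(-c3cn4ccccc4n3)o2)cc1` reaches only a limit of this assay, > 50000 nM. The change bromo in place of chloro on an aromatic carbon thus gives an at least 1.5-fold higher number from compound 1 to compound 2 (0.18 log units; that floor lies within the scatter), a step whose floor rests on (the limit of > 50000 nM in this assay, at which 1 of the 3 values shown sits). On the other core, compound 3 `Cc1cc(Br)c2nc(-c3nnc(-c4ccc(Cl)cc4)o3)cn2c1` gives 46000 nM; how that core differs from the core of compound 1 is not broken down here. Compound 4 `Cc1cc(Br)c2nc(-c3nnc(-c4ccc(Br)cc4)o3)cn2c1` carries the same change, (bromo in place of chloro on an aromatic carbon), at the same place. By analogy with the step from compound 1 to compound 2, the step from compound 3 to compound 4 is expected to be a 1.4-fold higher number from compound 3 to compound 4 (0.15 log units; within the scatter), which would put compound 4 close to or past the limit of this assay. Compound 4 is therefore estimated at 65000 nM, between 35000 nM and 120000 nM.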

Compound 4, half-maximal inhibitory concentration: 22300 nM
The estimate for compound 4 lay 2.9-fold (0.46 log units) above the measured number; the measured number lies below the stated range.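

On the core of compound 3, bromo in place of chloro gives a 2.1-fold lower number from compound 3 to compound 4 (0.31 log units; beyond the scatter) in this assay, so the change does not carry over unchanged from the core of compound 1: the same change on two cores in this assay, an at least 1.5-fold higher number (0.18 log units; that floor lies within the scatter) from compound 1 to compound 2 and a 2.1-fold lower number (0.31 log units; beyond the scatter) from compound 3 to compound 4, at least 3.1-fold (0.49 log units) apart, beyond the scatter of two such steps.
The earlier step rests on a limit of the assay, so it is known only as a floor: the limit of > 50000 nM in this assay, at which 1 of the 4 values shown sits.
These two pairs show that the core matters to this step, but they give no reason for the gap and no rule for any further core.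

Open, going by these compounds, is which difference between the two cores goes with the gap. Also open, on these data alone, is how an amine or a carboxylic acid in place of the halogen would read on either core.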